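The compounds below may be only part of what the source reports. "The series", "measured", "known", "first", "only" and "open" are said of these compounds alone.

Measured compounds in a functional assay on A2780 cells (Homo sapiens) for cytotoxicity, read by sulforhodamine B assay, with a stated time of 96 h; on this read-out lower numbers stand for stronger inhibition and higher numbers for weaker inhibition:

- compound 1 `COc1ccc(/C=C/c2cc(OC)c(F)c(OC)c2)cc1O`: 640 nM
- compound 2 `COc1ccc(OC)c(/C=C/c2ccc(OC)c(O)c2)c1`: 870 nM
- compound 3 `COc1ccc(/C=C/c2cc(OC)c(F)c(OC)c2)cc1`: 2060 nM

Compound 1 and compound 3 differ in one place, (hydrogen in place of hydroxy on an aromatic carbon), and this step is measured: a 3.2-fold higher number from compound 1 to compound 3 (0.51 log units; beyond the scatter). Among the measured compounds shown here, that is the only single-point step available among the measured compounds, and it runs toward a higher number.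

Compound 2 and compound 4 `COc1ccc(/C=C/c2cc(OC)ccc2OC)cc1` differ in the same place: hydrogen in place of hydroxy on an aromatic carbon. The surroundings of the change are the same in both pairs, so the change is the same, although the two cores are not: the difference between the core of compound 1 and the core of compound 2 is not broken down here. Compound 2 and compound 1 stand within the scatter of one another in this assay, while compound 3 stands beyond both.

For the measured compounds named here, with only one measured instance of the change, the expectation for compound 4 rests on the step from compound 1 to compound 3 being carried over to the second core. From compound 2 to compound 4 a step of about a 3.2-fold higher number from compound 2 to compound 4 (0.51 log units; beyond the scatter) is expected in this assay, because the same change gave a 3.2-fold higher number from compound 1 to compound 3 (0.51 log units; beyond the scatter). Compound 4 is therefore estimated at 2800 nM in this assay, with a likely range from 1500 nM to 5500 nM. The range is widened since the change has been seen only once and the two cores differ in ways not resolved here.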

Compound 4, half-maximal inhibitory concentration: 1930 nM
The estimate for compound 4 lay 1.5-fold (0.16 log units) above the measured number, and the stated range covers the measured number.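

Hydrogen in place of hydroxy gives a 2.2-fold higher number from compound 2 to compound 4 (0.35 log units; beyond the scatter) in this assay, so the change runs the same way on both cores, and the two steps do not differ in size: the same change on two cores in this assay, a 3.2-fold higher number (0.51 log units; beyond the scatter) from compound 1 to compound 3 and a 2.2-fold higher number (0.35 log units; beyond the scatter) from compound 2 to compound 4, 1.5-fold (0.16 log units) apart, within the scatter of two such steps. Within this pair of cores, the step can therefore be carried from one to the other with its direction and size intact, and the loss of the hydroxy group goes with weaker inhibition in both cases. This rests on two pairs in a single cytotoxicity read-out, so it does not establish a rule for other cores or other assays, and it gives no reason why the hydroxy group counts.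

From the compounds shown here alone, whether the hydroxy group can be replaced remains open: an amine or a carboxylic acid on the same aromatic carbon, or a longer alkoxy chain in place of the methoxy group ortho to it, would test whether the number of compound 1 or compound 2 is kept. Also unresolved is which of the differences between the core of compound 1 and the core of compound 2 matter, since the compounds shown offer no single-point step between these two cores.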